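The compounds below may be only part of what the source reports. "The series", "measured", "known", "first", "only" and "open" are said of these compounds alone.

Compound 1, `Cc1ccc(S(=O)(=O)NCc2ccc(CNC(=O)c3ccc(F)cn3)cc2)cc1`: 1000 nM
Compound 2, `O=C(NCc1ccc(CNS(=O)(=O)c2ccc([N+](=O)[O-])cc2)cc1)c1ccc(F)cc1`: 1000 nM

Of the compounds shown here, two have been measured in an assay on MDA-MB-231 cells for binding affinity to C-X-C chemokine receptor type 4 (Homo sapiens), read by fluorescence and microscopy, with stated times of 10 min and 30 min; on this read-out lower numbers stand for an effect already at smaller amounts and higher numbers for an effect only at larger amounts of compound. Compound 1 gives 1000 nM in this assay, and compound 2 gives 1000 nM. At the digits shown the two values are level, and the gap between them lies within the usual scatter of repeated measurements, so nothing can be said about one being stronger than the other. Within the data shown here, compound 1 and compound 2 also differ from each other in more than one place, so no single structural step between measured compounds is available to learn from.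

Compound 3, `O=C(NCc1ccc(CNS(=O)(=O)c2ccc(Cl)cc2)cc1)c1ccc(F)cc1`, has not yet been measured. It differs from compound 2 in one place only: chloro in place of nitro on an aromatic carbon. The measured pair gives no guidance on how a change of this kind moves the value in this assay. With nothing pointing either way, the step from compound 2 to compound 3 is expected to be small, and none beyond the scatter is expected: no change at the digits printed from compound 2 to compound 3 (within the scatter). Compound 3 is therefore estimated to give 1000 nM in this assay, within a range from 300 nM to 3000 nM.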

Compound 3, effective concentration (reported as EC, without a stated level of effect): 100 nM
Compound 3: middle estimate off by 10-fold (1.00 log units), on the high side, and the stated range ends above it.
By their numbers in this assay, from the lowest: compound 3; then compounds 1 and 2 (each within the scatter of the next).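

Putting chloro in place of nitro on this aromatic carbon gives a 10-fold lower number from compound 2 to compound 3 (1.00 log units; beyond the scatter) in this assay. Among these compounds, this is the first single-place change, and it shows that the group held at this position can shift the value by more than the usual scatter, something the level values of compound 1 and compound 2 could not show, as those two differ in more than one place. No measurement shown here accounts for the size or direction of this step, so the result records what happens at this position and not why it happens.

A single step cannot show how the value would respond to other groups at the same position, such as an amine, a methoxy group, a bromo group or a carboxylic acid, or whether any of them would sit closer to compound 3 or to compound 2. Also open, from the compounds shown here alone, is whether the change from 4-nitrophenyl to 4-chlorophenyl would have a similar effect if another part of the molecule were different, as one pair of compounds cannot establish a general pattern.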